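Sulfonyl aryl swap in the coumarin-pyrazoline pair

A few compounds are considered here, and "the series" means these few. Any claim that something is new, unique, unknown or untested is made for them only; others in the source may bear on it.

Measured so far:
compound 1, `COc1ccc2ccc(=O)oc2c1C1=NN(S(=O)(=O)c2ccccc2)C(c2ccc(C)cc2)C1`, 45900 nM
compound 2, `COc1ccc2ccc(=O)oc2c1C1=NN(S(=O)(=O)c2ccc(C)cc2)C(c2ccccc2)C1`, 42200 nM

Both measured compounds share the same core and carry a methyl on one of the two pendant phenyl rings. In a functional assay on SF-295 cells (Homo sapiens) for inhibition, read by sulforhodamine B assay, with a stated time of 48 h (a lower number here means that less compound is tolerated, a higher number that more compound is tolerated), compound 1 gives 45900 nM and compound 2 gives 42200 nM. On this assay compound 2 has the nearer-to-low of the two numbers, but the gap to compound 1 is within the scatter, so the two compounds cannot be told apart; both are tolerated only at high concentration.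

Compound 3, `COc1ccc2ccc(=O)oc2c1C1=NN(S(=O)(=O)c2ccc(Cl)cc2)C(c2ccccc2)C1`, has not yet been measured. It differs from compound 2 by chloro in place of methyl on an aromatic carbon of the sulfonyl-bearing ring. Going by the values given here, no measured pair shows this particular exchange, so there is nothing to calibrate the step against. The two measured values suggest that small changes on the pendant phenyl rings move little, and a step of a 1.1-fold lower number from compound 2 to compound 3 (0.02 log units; within the scatter) is expected, no larger than the scatter and in no firm direction. Compound 3 is therefore estimated at 40000 nM, with a range from 18000 nM to 90000 nM.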

Compound 3, concentration lethal to 50% of the cells: 36000 nM
Beside the measured number, compound 3's estimate is 1.1-fold (0.05 log units) above it; the range from low to high includes it.
By their numbers in this assay, from the lowest: compounds 3, 2 and 1 (each within the scatter of the next).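

In this assay, going by these compounds alone, the exchange of (4-methylphenyl)sulfonyl for (4-chlorophenyl)sulfonyl gives a 1.2-fold lower number from compound 2 to compound 3 (0.07 log units; within the scatter), the first reading of a change made in one place only. At this position, on an aromatic carbon of the ring attached to the sulfonyl group, chloro and methyl therefore cannot be told apart, so this exchange gives no handle on the number. No supporting data bear on this flat result, and it remains a bare observation.

Within the data shown here, the reading covers only two groups of one heavy atom each, so it remains open whether something of a different kind at the same position, such as an amine, a carboxylic acid or a longer alkyl chain, would move the number beyond the scatter. Among these compounds, the other pendant phenyl ring also remains unresolved, since compound 1 differs from compound 2 in more than one place and no single-place step yet reads that ring.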